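Propargylamino for dimethylamino on a pyridazinone cyanoguanidine series

The source may report more compounds than this note shows. Statements on the series, on what has been measured and on what is new or still open speak of the compounds shown alone.

Of the compounds shown here, three have been measured. Compound 1 `CN(C)/C(=N/CCCCn1nc(-c2ccccc2)ccc1=O)NC#N` gives 80.7% in a functional assay on the whole organism with Rattus norvegicus as the target, at a dose of 100 mg/kg; on this read-out higher numbers stand for more inhibition at the one dose given (going by the name of the read-out) and lower numbers for less inhibition. Compound 2 `C#CCN/C(=N/CCCCn1nc(-c2ccccc2)ccc1=O)NC#N` gives -12.9% in this assay. Compound 3 `CN(C)/C(=N/CCCn1nc(-c2ccccc2)ccc1=O)NC#N` gives 72.2% in this assay.

Compound 1 and compound 3 share much of their structure, but the difference between their two cores is not broken down here. Among the compounds with values here, the one counted change among the measured compounds is that from compound 1 to compound 2: propargylamino in place of dimethylamino on a carbon with a double bond to nitrogen This change made a very large step, a number 93.6 percentage points lower from compound 1 to compound 2 (beyond the scatter), turning a strong inhibition into essentially none at the dose given. Compound 3 sits within the usual scatter of compound 1, so the two cannot be placed in order, while compound 2 lies well below both.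

Compound 4 `C#CCN/C(=N/CCCn1nc(-c2ccccc2)ccc1=O)NC#N` is not yet measured. It differs from compound 3 by propargylamino in place of dimethylamino on a carbon with a double bond to nitrogen The place is described in the same words as for the step from compound 1 to compound 2, so this is the same change applied to the core of compound 3. Because a number 93.6 percentage points lower from compound 1 to compound 2 (beyond the scatter) was so large, the same change on compound 3 is expected to give a comparable fall, a number 82.2 percentage points lower from compound 3 to compound 4 (beyond the scatter). Within the data shown here, compound 4 is therefore estimated at -10% in this assay, with a likely range from -35% to 20%, resting on the single earlier step and on compound 3 starting near compound 1.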

Compound 4, a percentage reported as inhibition, in the whole organism at one dose (the size of the read-out at that dose, not a potency): -11.8%
Beside the measured number, compound 4's estimate is 1.8 percentage points above it; measured number inside the range.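

Propargylamino in place of dimethylamino on a carbon with a double bond to nitrogen again brought a large fall in this assay, a number 84 percentage points lower from compound 3 to compound 4 (beyond the scatter), so the loss seen on the core of compound 1 also appears on the core of compound 3. Set side by side, the two steps cannot be told apart in size, and in this small set the change carries from one core to the other: the same change on two cores in this assay, a number 93.6 percentage points lower (beyond the scatter) from compound 1 to compound 2 and a number 84 percentage points lower (beyond the scatter) from compound 3 to compound 4, 9.6 percentage points apart, within the scatter of two such steps. This rests on two pairs at a single dose, so it does not show that the change would behave the same way on any other core, how potency shifts, or why the read-out falls.

The compounds shown leave open which feature of the entering group goes with the loss, a question that methylamino, propylamino or allylamino on the same carbon could help to settle by separating the triple bond from the change of dimethylamino to a secondary amine. They also leave open whether a longer chain on the shared core would keep the same large gap between dimethylamino and propargylamino.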